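The compounds below may be only part of what the source reports. "The series", "measured", "known", "first", "only" and "open" are said of these compounds alone.

Measured so far in an assay on microsomes from intestine for inhibition of acyl-CoA:cholesterol acyltransferase (Oryctolagus cuniculus); on this read-out higher numbers stand for weaker inhibition and lower numbers for stronger inhibition:
compound 1 `CCCCCCOC(=O)NC(=O)Oc1c(C(C)C)cccc1C(C)C` gives 53 nM
compound 2 `CCCCCCCCCCCCOC(=O)NC(=O)Oc1c(C(C)C)cccc1C(C)C` gives 21 nM
compound 3 `CCCCCCCCCCCCCOC(=O)NC(=O)Oc1c(C(C)C)cccc1C(C)C` gives 9 nM

Compound 3 stands lowest of the three numbers in this assay; its nearest neighbour is compound 2 and its furthest is compound 1, both steps beyond the scatter.

Compound 4 `CCCCCCCCCCCCCCCCOC(=O)NC(=O)Oc1c(C(C)C)cccc1C(C)C` differs from compound 3 by propyl in place of hydrogen on a saturated chain carbon, ten or more bonds along the chain from an oxygen next to a carbonyl group. For the measured compounds named here, the steps that bear on this are those that lengthen the same chain: a 2.5-fold lower number from compound 1 to compound 2 (0.40 log units; beyond the scatter), a 5.9-fold lower number from compound 1 to compound 3 (0.77 log units; beyond the scatter) and a 2.3-fold lower number from compound 2 to compound 3 (0.37 log units; beyond the scatter). Each lengthening so far gave a lower number, the latest one by about the same size as the first. Nothing in the series shows where this ends; the change to compound 4 goes further out than any measured step, so a further but modest lowering is expected in this assay, with the chance that the gain has levelled off kept in the range. The expected step is a 1.8-fold lower number from compound 3 to compound 4 (0.26 log units; within the scatter). For compound 4 the estimate is 5 nM, between 2 nM and 15 nM.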

Compound 4, half-maximal inhibitory concentration: 50 nM
Estimate against measurement, compound 4: 10-fold (1.00 log units) below; the whole stated range lies below it.
By their numbers in this assay, from the lowest: compound 3; then compound 2; then compounds 4 and 1 (each within the scatter of the next).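

In this assay lengthening the chain stops lowering the number: the direction seen from compound 1 through compound 2 to compound 3 reverses with propyl in place of hydrogen on a saturated chain carbon (a 5.6-fold higher number from compound 3 to compound 4 (0.74 log units; beyond the scatter)). The rise carries past the earlier chain length (a 2.4-fold higher number from compound 2 to compound 4 (0.38 log units; beyond the scatter)), and the whole gain from lengthening is gone, with the longest chain shown and the shortest level (a 1.1-fold lower number from compound 1 to compound 4 (0.03 log units; within the scatter)). Among these four chains the response therefore turns, with compound 3 lowest, and nothing at hand accounts for the turn.

Going by these compounds, whether methyl or ethyl in place of hydrogen on the chain of compound 3 would keep the low number stays open. On these data alone, how an amine or a carboxylic acid in place of the propyl would read is also open.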